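Mirror-Image Cyclopropane Amide: Expected Agonist Response

This account rests on a few compounds, and the source may have more. Where it says the series, first, only, none or still open, it means among the compounds named here.

Compound 3 `C[C@@H]1C[C@@H]1C(=O)N1CC2CC(C1)N2` is the starting point. Going by the values given here, in an assay on SH-EP1 cells for agonist activity at Neuronal acetylcholine receptor; alpha4/beta2 (Homo sapiens), read by FLIPR and calcium flux (on this read-out lower numbers stand for smaller maximal responses and higher numbers for larger maximal responses), compound 3 gives 97%, the lowest of the three numbers measured so far. Its nearest neighbour is compound 1 `O=C(C1CCC1)N1CC2CC(C1)N2`, which in this assay gives 99%; the step of a number 2 percentage points lower from compound 1 to compound 3 (within the scatter) lies within the scatter. Compound 2 `O=C([C@@H]1C[C@@H]1F)N1CC2CC(C1)N2` gives 110% in this assay, and the step of a number 13 percentage points lower from compound 2 to compound 3 (beyond the scatter) is beyond the scatter, as is the step of a number 11 percentage points higher from compound 1 to compound 2 (beyond the scatter).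

Compound 4 `C[C@H]1C[C@H]1C(=O)N1CC2CC(C1)N2` is the compound now in question. Compared with compound 3: the two compounds have the same atoms and bonds; at least one stereo element is drawn with a configuration in one of them and without one in the other: 2 of 4 stereo elements differ; a stereocentre at a saturated ring carbon is drawn R in compound 3 and S in compound 4; a stereocentre at a saturated ring carbon is drawn S in compound 3 and R in compound 4. Among the compounds with values here, none of the measured steps concerns such a change; each of them exchanges one group on the carbonyl carbon for another, so no measured step bears directly on the move to compound 4. The expectation is therefore of no step beyond the scatter, and compound 4 is expected to give 97% in this assay, with a range from 82% to 112%. The step of no change at the digits printed from compound 3 to compound 4 (within the scatter) is expected to be small.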

Compound 4, largest response reached (Emax), in percent of the reference or control that the assay uses: 93%
The estimate for compound 4 lay 4 percentage points above the measured number; low and high end bracket the measured number.
By their numbers in this assay, from the lowest: compounds 4, 3 and 1 (each within the scatter of the next); then compound 2.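

In this assay, inverting both stereocentres at the saturated ring carbons gives a number 4 percentage points lower from compound 3 to compound 4 (within the scatter), so this read-out does not separate the two drawn configurations of the 2-methylcyclopropyl amide. The second configuration behaves like the first towards the other two compounds: 2-methylcyclopropyl in place of cyclobutyl gives a number 6 percentage points lower from compound 1 to compound 4 (within the scatter), while methyl in place of fluoro on a saturated ring carbon gives a number 17 percentage points lower from compound 2 to compound 4 (beyond the scatter), so only compound 2 stands apart. How far the pair can be read as a clean stereo comparison is limited by how the structures are drawn: the fact that one of compounds 3 and 4 is drawn with a defined configuration and the other without, at the place where they differ.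

The compounds shown leave open whether compound 2 would likewise hold its number with both ring stereocentres inverted. They also leave open how an ethyl or a hydroxyl group in place of methyl on that ring carbon would read.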